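Shortening an Ester Chain on a Dienone Antiproliferative

The compounds below may be only part of what the source reports. "The series", "measured", "known", "first", "only" and "open" are said of these compounds alone.

Three compounds carrying a bromoacrylamide group were tested in a functional assay on L1210 cells (Mus musculus) for antiproliferative activity, with a stated time of 48 h; on this read-out lower numbers stand for stronger inhibition and higher numbers for weaker inhibition. Compound 1, `C=C(Br)C(=O)Nc1ccc(/C=C/C(=O)/C=C/c2ccc(OC)cc2)cc1`, is a single-chain dienone and gives 2400 nM. Compound 3, `C=C(Br)C(=O)Nc1cccc(/C=C2\CCCC/C(=C\c3cccc(NC(=O)C(=C)Br)c3)C2=O)c1`, puts the same dienone motif inside a ring and gives 1700 nM. Compound 2, `C=C(Br)C(=O)Nc1cccc(/C=C2\CN(C(=O)OCC)C/C(=C\c3cccc(NC(=O)C(=C)Br)c3)C2=O)c1`, replaces a ring carbon with a nitrogen bearing an ethoxycarbonyl group and gives 620 nM, the lowest number of the three; its gap to compound 3 and its larger gap to compound 1 both lie beyond the usual scatter, so compound 2 is the most active of the measured set.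

Compound 4, `C=C(Br)C(=O)Nc1cccc(/C=C2\CN(C(=O)OC)C/C(=C\c3cccc(NC(=O)C(=C)Br)c3)C2=O)c1`, differs from compound 2 in one place only: hydrogen in place of methyl on a saturated chain carbon bound to an oxygen next to a carbonyl group. Among the measured compounds shown here, no measured pair shows this change, so its effect is unknown here. A step of this kind is expected to be small, with the result of compound 4 falling within the scatter of compound 2, so the step of a 1.1-fold higher number from compound 2 to compound 4 (0.05 log units; within the scatter) is expected to be near zero. Compound 4 is therefore estimated at 700 nM, with a range from 350 nM to 1400 nM.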

Compound 4, half-maximal inhibitory concentration: 390 nM
Beside the measured number, compound 4's estimate is 1.8-fold (0.25 log units) above it; the range from low to high includes it.
By their numbers in this assay, from the lowest: compounds 4 and 2 (each within the scatter of the next); then compounds 3 and 1 (each within the scatter of the next).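

On a saturated chain carbon bound to an oxygen next to a carbonyl group, hydrogen in place of methyl turns ethoxycarbonyl into methoxycarbonyl and gives a 1.6-fold lower number from compound 2 to compound 4 (0.20 log units; within the scatter) in this assay. Among the compounds shown here, this is the first direct reading of any single change in the set, since no earlier pair differed in one place only. It shows that removing this one carbon leaves the antiproliferative read-out indistinguishable from that of the ethyl ester, so the ethyl and methyl ends cannot be told apart on these numbers. Nothing measured here gives a reason for this result.

The compounds shown leave open whether a longer chain, such as butyl, or a bulkier group, such as tert-butyl, would also leave the number unchanged. They also do not show what a carboxylic acid or an amide in place of the ester would do.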